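Isopropyl for aminoethyl on the ring nitrogen

A few compounds are considered here, and "the series" means these few. Any claim that something is new, unique, unknown or untested is made for them only; others in the source may bear on it.

Measured compounds in an assay for inhibition of Tryptophan 2,3-dioxygenase (Homo sapiens), with stated times of 10 min and 60 min, tested at 10 uM; a higher number here means a stronger effect of the compound at the concentration tested, a lower number a weaker effect:
compound 1, `NCCn1ncc2c(NCc3ccccc3[N+](=O)[O-])cc(C(F)(F)F)cc21`: 25%
compound 2, `COC(=O)c1cc(NCc2ccccc2[N+](=O)[O-])c2cn[nH]c2c1`: 16%
compound 3, `FC(F)(F)c1cc(NC[C@@H]2CCCCN2)c2cn[nH]c2c1`: 64%

Among these three numbers compound 1 stands second highest. Its nearest neighbour is compound 2, whose reading lies within the usual scatter of the number for compound 1, so no order between the two can be drawn from these data. The furthest away is compound 3, whose reading is higher than that of compound 1 by a margin beyond the scatter. Among the compounds with values here, no pair of measured compounds differs in a single place, so no step between them can be quoted, and nothing connects the size of compound 3's reading to one structural feature.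

Compound 4, `CC(C)n1ncc2c(NCc3ccccc3[N+](=O)[O-])cc(C(F)(F)F)cc21`, differs from compound 1 in one place: isopropyl in place of 2-aminoethyl on an aromatic nitrogen. Within the data shown here, no measured pair shows this exchange, and the three measured compounds give no ground for a direction. The expected step is therefore small, no change at the digits printed from compound 1 to compound 4 (within the scatter), not beyond the scatter, with wide uncertainty in both directions. Compound 4 is estimated at 25%, with a range from 5% to 50%.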

Compound 4, a percentage reported as inhibition, at one concentration (the size of the read-out at that concentration, not a potency): 35%
Estimate against measurement, compound 4: 10 percentage points below; the measured number falls inside the stated range.
By their numbers in this assay, from the lowest: compounds 2, 1 and 4 (each within the scatter of the next, the first and the last beyond it); then compound 3.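

In this assay, isopropyl in place of 2-aminoethyl on an aromatic nitrogen gives a number 10 percentage points higher from compound 1 to compound 4 (within the scatter) and so leaves no reading that can be separated from that of compound 1. For this pair, the position accepts a group with 0 hydrogen-bond donors and 0 hydrogen-bond acceptors, so the primary amine of the 2-aminoethyl group is not required to keep the reading of compound 1 at the concentration tested, although this rests on a single exchange on a single core. No measurement of any property of these compounds bears on this step, and the pair offers no explanation for it.

From the compounds shown here alone, a longer chain such as 3-aminopropyl, a carboxylic acid on a short chain, or plain hydrogen at this nitrogen on the core of compound 1 remains open, so the limits of what this position accepts are still undefined. Also open, going by these compounds, is whether the same exchange would leave the reading unchanged with the side chain of compound 3, which gives 64% in this assay.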